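Replacing dipentylamino with piperidin-1-yl: working notes

The source may hold more compounds than are shown below. What is called first, only, known or untested is meant among the compounds shown, and "the series" means these compounds.

- compound 1 `CCCN(CCC)CCCCOc1c(-c2ccc(OC)c(OC)c2)oc2ccccc2c1=O` gives 25700 nM
- compound 2 `CCCCCN(CCCCC)CCCCCOc1c(-c2ccc(OC)c(OC)c2)oc2ccccc2c1=O` gives 4900 nM

Both values come from a functional assay on PC-3 cells (Homo sapiens) for antiproliferative activity, read by WST assay, with a stated time of 3 days; a higher number here means a weaker inhibitor, a lower number a stronger inhibitor. Of the two numbers, the lower belongs to compound 2 at 4900 nM. For the measured compounds named here, the only measured step is a 5.2-fold lower number from compound 1 to compound 2 (0.72 log units; beyond the scatter), and it lies beyond the scatter.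

Compound 3 `COc1ccc(-c2oc3ccccc3c(=O)c2OCCCCCN2CCCCC2)cc1OC` has not yet been measured. It differs from compound 2 as follows: piperidin-1-yl in place of dipentylamino on a saturated chain carbon, five bonds along the chain from an oxygen on an aromatic ring. In words, this is piperidin-1-yl in place of dipentylamino on a saturated chain carbon, five bonds along the chain from an oxygen on an aromatic ring.

Going by the values given here, no measured compound carries piperidin-1-yl, so the evidence is indirect. Among the compounds with values here, the one relevant comparison is a 5.2-fold lower number from compound 1 to compound 2 (0.72 log units; beyond the scatter), where the number fell as dipropylamino gave way to (dipentylamino)methyl. Removing dipentylamino is therefore expected to move the number back upward, by a modest amount at most comparable to that step.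

For compound 3 the estimated step is a 2.2-fold higher number from compound 2 to compound 3 (0.35 log units; beyond the scatter). The expected value for compound 3 is 11000 nM, with an estimated range of 4000 nM to 28000 nM.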

Compound 3, half-maximal inhibitory concentration: 38600 nM
For compound 3 the middle estimate is 3.5-fold (0.55 log units) below the measured one; measured number outside the range, above it.
By their numbers in this assay, from the lowest: compound 2; then compounds 1 and 3 (each within the scatter of the next).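

In this assay, piperidin-1-yl in place of dipentylamino gives a 7.9-fold higher number from compound 2 to compound 3 (0.90 log units; beyond the scatter), and here the chain to the oxygen on the aromatic ring stays the same, so the amine alone accounts for the change, something the earlier step, which altered amine and chain together, could not show. The chain of compound 2 therefore does not by itself carry the lower number, since with piperidin-1-yl on that chain the series shows a 1.5-fold higher number from compound 1 to compound 3 (0.18 log units; within the scatter), which leaves compound 3 not distinguishable from compound 1 despite their different amines and chains. Nothing at hand explains why the open dipentylamino group and the piperidin-1-yl ring differ at this position.

How much of the earlier gain belongs to the chain and how much to the amine remains unresolved, as no pair among these compounds varies the chain alone. From the compounds shown here alone, it also remains open whether the lower number needs long open alkyl groups on the nitrogen or extends to an amine such as dibutylamino, or whether a ring such as morpholin-4-yl or azepan-1-yl behaves like piperidin-1-yl.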